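Swapping 4-bromophenyl for 2-hydroxyphenyl on an aromatic nitrogen

The source may hold more compounds than are shown below. What is called first, only, known or untested is meant among the compounds shown, and "the series" means these compounds.

Of the compounds shown here, three sharing one core have been measured in a functional assay on A549 cells (Homo sapiens) for inhibition, read by MTT assay, with a stated time of 24 h; a higher number here means a weaker inhibitor, a lower number a stronger inhibitor. Compound 1 (`CC1(C)[C@H]2CC[C@]1(C)N(Cc1cn(-c3ccccc3C#N)nn1)C(=O)C2`) gives 100 nM, compound 2 (`CC1(C)[C@H]2CC[C@]1(C)N(Cc1cn(-c3ccccc3)nn1)C(=O)C2`) gives 70 nM, and compound 3 (`CC1(C)[C@H]2CC[C@]1(C)N(Cc1cn(-c3ccc(Br)cc3)nn1)C(=O)C2`) gives 80 nM. Compound 3 thus stands within the scatter of both of the others. The next compound, compound 4 (`CC1(C)[C@H]2CC[C@]1(C)N(Cc1cn(-c3ccccc3O)nn1)C(=O)C2`), carries 2-hydroxyphenyl in place of 4-bromophenyl on an aromatic nitrogen. Within the data shown here, three measured steps bear on this change. They are a 1.3-fold lower number from compound 1 to compound 3 (0.10 log units; within the scatter), a 1.1-fold higher number from compound 2 to compound 3 (0.06 log units; within the scatter) and a 1.4-fold lower number from compound 1 to compound 2 (0.15 log units; within the scatter), and each lies within the scatter. Among the measured compounds shown here, none of the measured compounds carries 2-hydroxyphenyl, so the data offer only indirect guidance and the range must stay wide. For the measured compounds named here, compound 1 and compound 3 differ in this same place, and a 1.3-fold lower number from compound 1 to compound 3 (0.10 log units; within the scatter) is the closest precedent. On that basis, no change beyond the scatter is expected, and the estimated step is a 1.1-fold higher number from compound 3 to compound 4 (0.03 log units; within the scatter). For compound 4 the expected value is 85 nM, with an estimated range from 35 nM to 200 nM.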

Compound 4, half-maximal inhibitory concentration: 230 nM
For compound 4 the middle estimate is 2.7-fold (0.43 log units) below the measured one; the measured number lies above the stated range.
By their numbers in this assay, from the lowest: compounds 2, 3 and 1 (each within the scatter of the next); then compound 4.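

Up to this point, the changes on the aromatic nitrogen had all stayed within the scatter in this assay, so the position looked tolerant; 2-hydroxyphenyl is the first group here to move the number beyond it, with a 2.9-fold higher number from compound 3 to compound 4 (0.46 log units; beyond the scatter), a 3.3-fold higher number from compound 2 to compound 4 (0.52 log units; beyond the scatter) and a 2.3-fold higher number from compound 1 to compound 4 (0.36 log units; beyond the scatter). Among these compounds, compound 4 is therefore the weakest inhibitor of the four, and it is also the only one whose group counts a hydrogen-bond donor, although four compounds cannot tie the two facts together. Nothing in the data shown explains this loss.

The compounds shown leave open whether the loss belongs to the hydroxy itself or to where it sits on the ring. A 4-hydroxyphenyl, 2-methoxyphenyl or 2-aminophenyl group on the same nitrogen would separate these readings.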